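A few compounds are considered here, and "the series" means these few. Any claim that something is new, unique, unknown or untested is made for them only; others in the source may bear on it.

Working notes on a small set tested in a functional assay on RD cells (Homo sapiens) for inhibition, read by luminescence and ATP content, with a stated time of 72 h; a higher number here means that more compound is tolerated, a lower number that less compound is tolerated. Compound 1 `Cc1nc(-c2cnc3ccc(-c4ccc(N)cc4)cc3c2)no1` and compound 2 `CCCCc1nc(-c2cnc3ccc(-c4ccc(N)cc4)cc3c2)no1` share one core and differ only in the chain carried on it. In this assay compound 1 gives only a limit, > 2500 nM. Compound 2 likewise gives only a limit, > 2500 nM. The change from compound 2 to compound 1 is hydrogen in place of propyl on a saturated chain carbon bound to an aromatic carbon, and the step that the two limits leave unreadable from compound 2 to compound 1 cannot be sized because both values sit at the limit of > 2500 nM in this assay, at which 2 of the 3 values shown sit.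

Compound 3 `CCCCc1ccc(-c2ccc3ncc(-c4noc(C(F)(F)F)n4)cc3c2)cc1` is built on a different core; how it differs from compound 2 is not broken down here. In this assay compound 3 also gives only a limit, > 7400 nM, which is the limit of > 7400 nM in this assay, at which 1 of the 3 values shown sits.

Compound 4 `Cc1ccc(-c2ccc3ncc(-c4noc(C(F)(F)F)n4)cc3c2)cc1` is compound 3 carrying the same change, (hydrogen in place of propyl on a saturated chain carbon bound to an aromatic carbon), at the same place. The step expected from compound 3 to compound 4 is a step that the limit leaves unreadable from compound 3 to compound 4, resting on compound 2 and compound 1 both remaining at the limit of > 2500 nM in this assay, at which 2 of the 3 values shown sit, across this change. For compound 4 the expected value is 10000 nM, estimated to lie between 3000 nM and 30000 nM, with the assay most likely reporting only a limit once more.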

Compound 4, half-maximal cytotoxic concentration: > 22200 nM
Compound 4: a limit, no number (the forecaster's own chance of this, stated with the estimate: 80%); at least 2.2-fold (0.34 log units) between middle value and limit.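

Compound 4 gives only a limit in this assay, > 22200 nM, and compound 3 also gives only a limit, so no step can be read between compound 3 and compound 4. The compounds shown leave open how much of any of them is tolerated, and whether hydrogen in place of propyl at this place changes that at all.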